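The source may hold more compounds than are shown below. What is called first, only, known or untested is meant among the compounds shown, and "the series" means these compounds.

In an ADME assay on BHK-21 cells (Mesocricetus auratus) for cytotoxicity, read by MTT assay, with a stated time of 72 h (on this read-out lower numbers stand for higher toxicity in this test and higher numbers for lower toxicity in this test), compound 3 (`NS(=O)(=O)c1ccc(N2N=C(c3ccc(Oc4ccccc4)cc3)CC2c2ccccc2Cl)cc1`) gives 8000 nM and stands level with compound 2 (`Cc1cccc(C2CC(c3ccc(Oc4ccccc4)cc3)=NN2c2ccc(S(N)(=O)=O)cc2)c1`) at 8000 nM while compound 1 (`NS(=O)(=O)c1ccc(N2N=C(c3ccc(Oc4ccccc4)cc3)CC2c2ccccc2)cc1`) gives 11000 nM within the scatter of both. Compound 4 (`Cc1ccccc1C1CC(c2ccc(Oc3ccccc3)cc2)=NN1c1ccc(S(N)(=O)=O)cc1`) carries methyl in place of chloro on an aromatic carbon, ortho to a large group (methyl in place of chloro on an aromatic carbon). Going by the values given here, three measured steps bear on this. Methyl in place of hydrogen gave a 1.4-fold lower number from compound 1 to compound 2 (0.14 log units; within the scatter) and chloro in place of hydrogen gave a 1.4-fold lower number from compound 1 to compound 3 (0.14 log units; within the scatter) while 2-chlorophenyl in place of 3-methylphenyl gave no change at the digits printed from compound 2 to compound 3 (within the scatter) in the same test. The expected step is no change at the digits printed from compound 3 to compound 4 (within the scatter) in this assay and so none beyond the scatter. For compound 4 the estimate is 8000 nM with an expected range from 4500 nM to 14000 nM on these few numbers.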

Compound 4, half-maximal cytotoxic concentration: 7000 nM
The estimate for compound 4 lay 1.1-fold (0.06 log units) above the measured number; measured number inside the range.
By their numbers in this assay, from the lowest: compounds 4, 2, 3 and 1 (each within the scatter of the next).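

In this assay methyl in place of chloro gives a 1.1-fold lower number from compound 3 to compound 4 (0.06 log units; within the scatter) and so does not separate the two groups at this position. 2-methylphenyl in place of 3-methylphenyl gives a 1.1-fold lower number from compound 2 to compound 4 (0.06 log units; within the scatter) and methyl in place of hydrogen gives a 1.6-fold lower number from compound 1 to compound 4 (0.20 log units; within the scatter) so neither the place of the methyl nor its presence separates these compounds in this test. On these data alone, whether an amine or a carboxylic acid at this position would give a step beyond the scatter stays open. Nothing given here speaks to why these numbers sit so close.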